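Selenium and a Benzyl Group Replace Methylsulfanyl

The compounds below may be only part of what the source reports. "The series", "measured", "known", "first", "only" and "open" are said of these compounds alone.

The measured compounds share a core in which an imine carbon is flanked by two amide-type nitrogens, each carrying an aromatic acyl group. In a functional assay on PC-3 cells (Homo sapiens) for cytotoxicity, read by MTT assay, with a stated time of 72 h (on this read-out lower numbers stand for stronger inhibition of growth and higher numbers for weaker inhibition of growth), compound 1 `C[Se]/C(=N\C(=O)c1cc2ccccc2s1)NC(=O)c1cc2ccccc2s1` gives 65600 nM, and compound 2 `CS/C(=N\C(=O)c1sccc1Cl)NC(=O)c1sccc1Cl` gives 57400 nM. Compound 3 `CS/C(=N\C(=O)c1ccno1)NC(=O)c1ccno1` is reported only as a limit of this assay, > 100000 nM. It thus stands at the limit of > 100000 nM in this assay, at which 1 of the 3 values shown sits, not as a number. Compound 4 `O=C(/N=C(/NC(=O)c1ccno1)[Se]Cc1ccccc1)c1ccno1` differs from compound 3 by a group of 8 heavy atoms (7 carbon, 1 selenium; one six-membered aromatic ring of carbon only) in place of a group of 2 heavy atoms (1 carbon, 1 sulfur; no ring), on a carbon with a double bond to nitrogen. Among the compounds with values here, no measured pair shows this change, so no step size can be read from the data. Compound 4 is expected to show a number no higher from compound 3 to compound 4 (the limit leaves the size open), no change beyond the scatter. Compound 4 is therefore estimated at 100000 nM, with a range from 40000 nM to 250000 nM, and a limit rather than a number remains likely.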

Compound 4, concentration for total growth inhibition: > 100000 nM
Compound 4: only a limit was reported; the forecaster's own chance of this, stated with the estimate: 55%; the middle value lies on the limit itself.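

Compound 3 and compound 4 are both reported only as limits, so no step can be read between them: the limit of > 100000 nM in this assay, at which 2 of the 4 values shown sit.

The compounds shown leave open whether the group entering in place of methylsulfanyl changes growth inhibition in this assay at all.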